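The source may hold more compounds than are shown below. What is called first, only, known or untested is meant among the compounds shown, and "the series" means these compounds.

In an ADME assay on microsomes from liver (Homo sapiens) for metabolic stability, with a stated time of 10 min (on this read-out higher numbers stand for a more stable compound and lower numbers for a less stable compound), compound 1 (`FC(F)(F)c1ccccc1-c1ccc2[nH]c(C3=NC4(CCCCC4)CO3)nc2c1`) gives 85% and compound 2 (`Fc1cc(-c2ccccc2C(F)(F)F)cc2nc(C3=NOC4(CCCCC4)C3)[nH]c12`) gives 46% as the lower of the two numbers, with a gap between them that lies beyond the scatter. These two compounds differ in more than one place, so they offer no single-change step to reason from. Compound 3 (`N#Cc1cc(-c2ccccc2C(F)(F)F)cc2nc(C3=NOC4(CCCCC4)C3)[nH]c12`) departs from compound 2 in one place: cyano in place of fluoro on an aromatic carbon, ortho to a fused ring and meta to a 2-(trifluoromethyl)phenyl group (cyano in place of fluoro on an aromatic carbon). Within the data shown here, no measured pair shows this swap, so the expectation in this assay is only a modest rise that may not clear the scatter. The expected change, a number 8 percentage points higher from compound 2 to compound 3 (within the scatter) as estimated here, stays small and uncertain. Compound 3 is expected to give 54% as a rough estimate (estimated range 32% to 76%).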

Compound 3, percent of the compound remaining: 68%
Compound 3: middle estimate off by 14 percentage points, on the low side; the range from low to high includes it.
By their numbers in this assay, from the lowest: compound 2; then compound 3; then compound 1.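

In this assay, cyano in place of fluoro on the aromatic carbon ortho to a fused ring and meta to a 2-(trifluoromethyl)phenyl group gives a number 22 percentage points higher from compound 2 to compound 3 (beyond the scatter), the first single-change step among these compounds. The read-out at this position is therefore not indifferent to the group it carries: exchanging the single fluorine for the two-atom cyano group moves the number beyond the scatter while the rest of the structure stays the same. No measurement here bears on what lies behind this rise.

The compounds shown leave open how an amine or a carboxylic acid on this same aromatic carbon would read. They also leave open whether the step would hold with another group in place of the 2-(trifluoromethyl)phenyl group.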